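The source may report more compounds than this note shows. Statements on the series, on what has been measured and on what is new or still open speak of the compounds shown alone.

Measured so far:
compound 1, `N=C(N)N/N=C/c1ccc(/C=C/C(=O)c2cccc(Cl)c2)cc1` — 80.7%
compound 2, `O=C(N/N=C/c1ccc(/C=C/C(=O)c2ccc(Cl)cc2Cl)cc1)c1ccncc1` — 83.8%

In a functional assay on the whole organism (Ear) for inhibition, with Mus musculus as the target, with a stated time of 30 min, at a dose of 100 mg/kg by the intraperitoneal route (on this read-out lower numbers stand for less inhibition and higher numbers for more inhibition at the one dose given (going by the name of the read-out)), compound 1 gives 80.7%, the lower of the two numbers shown, while compound 2 gives 83.8%, a gap within the scatter, so the two are not distinguished. Compound 3, `N=C(N)N/N=C/c1ccc(/C=C/C(=O)c2ccccc2Br)cc1`, differs from compound 1 by 2-bromophenyl in place of 3-chlorophenyl on a carbonyl carbon. Going by the values given here, no step between measured compounds covers a change of this kind; the only guide is that both measured compounds sit close together in this assay. The step expected is a number 3.7 percentage points lower from compound 1 to compound 3 (within the scatter), none beyond the scatter. Compound 3 is estimated at 77%, with a range from 60% to 90%.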

Compound 3, a percentage reported as inhibition, in the whole organism at one dose (the size of the read-out at that dose, not a potency): 78.3%
Beside the measured number, compound 3's estimate is 1.3 percentage points below it; the range from low to high includes it.
By their numbers in this assay, from the lowest: compounds 3, 1 and 2 (each within the scatter of the next).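

With 2-bromophenyl in place of 3-chlorophenyl on a carbonyl carbon, this assay gives a number 2.4 percentage points lower from compound 1 to compound 3 (within the scatter) for the first step read at this position. The exchange of halogen and its placing on the phenyl is therefore not distinguished at this one dose. Nothing measured here offers an explanation for this result.

Still open, on these data alone, is whether a phenyl carrying an amine or a carboxylic acid at this position would give a step beyond the scatter. A single dose also leaves potency unresolved.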